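Series notes: compound 2 to compound 3 in growth inhibition

This account rests on a few compounds, and the source may have more. Where it says the series, first, only, none or still open, it means among the compounds named here.

Among the compounds with values here, in a functional assay on SNB-19 cells (Homo sapiens) for inhibition (a lower number here means a stronger inhibitor of growth, a higher number a weaker inhibitor of growth), compound 1 `O=C(/C=C/c1cccc(O)c1)c1cccc(-n2cc(-c3ccccc3)[nH]c2=O)c1` gives 10900 nM and compound 2 `O=C(/C=C/c1cccc(O)c1)c1cccc(-n2cc(-c3ccc(Cl)cc3)[nH]c2=O)c1` gives 1920 nM, the lowest of the two numbers, with a 5.7-fold lower number from compound 1 to compound 2 (0.75 log units; beyond the scatter) the only measured step so far. Compound 3 `COc1cc(/C=C/C(=O)c2cccc(-n3cc(-c4ccc(Cl)cc4)[nH]c3=O)c2)ccc1O` carries 4-hydroxy-3-methoxyphenyl in place of 3-hydroxyphenyl on a double-bonded chain carbon bound to a double-bonded chain carbon. Within the data shown here, no measured step bears on this part of the shared core; the single step, chloro in place of hydrogen, sits elsewhere and offers no guide here, so the expected step is a 1.0-fold higher number from compound 2 to compound 3 (0.02 log units; within the scatter), none beyond the scatter. Compound 3 is therefore estimated at 2000 nM, within 700 nM to 6000 nM.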

Compound 3, concentration for 50% growth inhibition: 3170 nM
Beside the measured number, compound 3's estimate is 1.6-fold (0.20 log units) below it; measured number inside the range.
By their numbers in this assay, from the lowest: compounds 2 and 3 (each within the scatter of the next); then compound 1.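

In this assay, within the data shown here, the replacement gives a 1.7-fold higher number from compound 2 to compound 3 (0.22 log units; within the scatter), the first reading at this position on a double-bonded chain carbon bound to a double-bonded chain carbon. With 4-hydroxy-3-methoxyphenyl in place of 3-hydroxyphenyl, the larger group leaves compound 3 not separable from compound 2, so this one change shows that the position accepts it. No available evidence bears on this result.

The compounds shown leave open how the hydroxy and methoxy groups count separately, as both differ in this one step. A 4-hydroxyphenyl, a 3-methoxyphenyl or an aminophenyl group here would test that further.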